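Replacing hydroxy(methyl)amino with amino on the carbonyl

A few compounds are considered here, and "the series" means these few. Any claim that something is new, unique, unknown or untested is made for them only; others in the source may bear on it.

Compound 2 `COc1ccccc1C(=O)N(C)O` is a small aromatic amide carrying a hydroxy(methyl)amino group on its carbonyl carbon, and it was tested in an ADME assay on Huh-7 cells (Homo sapiens) for cytotoxicity, read by MTT assay, with a stated time of 72 h; on this read-out higher numbers stand for lower toxicity in this test and lower numbers for higher toxicity in this test. In this assay compound 2 gives > 800000 nM, which is a limit of the test and not a measured number. Its nearest relative, compound 1 `CN(O)C(=O)c1ccccc1O`, differs only by a methyl in place of hydrogen on an oxygen on an aromatic ring. In this assay compound 1 gives > 800000 nM, again a limit rather than a number. The step that the two limits leave unreadable from compound 1 to compound 2 therefore cannot be read; all that the pair shows is the limit of > 800000 nM in this assay, at which 2 of the 2 values shown sit.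

Compound 3 `COc1ccccc1C(N)=O` is the next compound to be measured. Its change from compound 2 is amino in place of hydroxy(methyl)amino on a carbonyl carbon. For the measured compounds named here, no measured step bears directly on this change, since the only step available is unreadable. With both known values sitting at the limit, the expectation is that compound 3 also reaches that limit rather than showing toxicity. Compound 3 is estimated at 800000 nM in this assay, within a range from 400000 nM to 1600000 nM. This estimate would mean an expected step of a number no higher from compound 2 to compound 3 (the limit leaves the size open).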

Compound 3, half-maximal cytotoxic concentration: > 800000 nM
Compound 3: only a limit was reported (the forecaster's own chance of this, stated with the estimate: 80%); the middle value sits exactly at the limit.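

Compound 2 and compound 3 both end at a limit of the test rather than at a measured number, so no step between them can be read: the limit of > 800000 nM in this assay, at which 3 of the 3 values shown sit.

The compounds shown leave open whether amino in place of hydroxy(methyl)amino on the carbonyl carbon changes anything in this assay, as none of them gives a measured number there.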